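Fluorines on the pendant phenyl of a fatty-acid receptor agonist

A few compounds are considered here, and "the series" means these few. Any claim that something is new, unique, unknown or untested is made for them only; others in the source may bear on it.

Measured so far:
compound 1, `CC#CC(CC(=O)O)c1ccc(OCc2ccc3nc(-c4ccc(CC)cc4)cn3c2)cc1`, 496 nM
compound 2, `CC#CC(CC(=O)O)c1ccc(OCc2ccn3cc(-c4ccc(C(C)C)cc4)nc3c2)cc1`, 615 nM
compound 3, `CC#CC(CC(=O)O)c1ccc(OCc2ccn3cc(-c4ccc(C)cc4)nc3c2)cc1`, 618 nM

All three compounds were tested in an assay on isolated protein for agonist activity at Free fatty acid receptor 1 (Homo sapiens); a higher number here means that more compound is needed for the effect, a lower number that less compound is needed. Compound 1 gives 496 nM, and its number is not separated from that of compound 2 or of compound 3 by more than the usual scatter, so the three stand together. Among the measured compounds shown here, the one single-point step among them, a 1.0-fold higher number from compound 2 to compound 3 (0.00 log units; within the scatter), changes the group on the pendant phenyl without moving the number.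

Compound 4, `CC#CC(CC(=O)O)c1ccc(OCc2ccc3nc(-c4ccc(F)cc4F)cn3c2)cc1`, differs from compound 1 in one place: 2,4-difluorophenyl in place of 4-ethylphenyl on an aromatic carbon. For the measured compounds named here, the step from compound 2 to compound 3 is the only measured change on that phenyl, and it was flat; it does not cover fluorine, and no measured pair does. On that evidence, compound 4 is expected to show no step beyond the scatter in this assay, that is a 1.2-fold higher number from compound 1 to compound 4 (0.08 log units; within the scatter). The estimate for compound 4 is 600 nM, with a range from 200 nM to 2000 nM.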

Compound 4, half-maximal effective concentration: 825 nM
Beside the measured number, compound 4's estimate is 1.4-fold (0.14 log units) below it; the measured number falls inside the stated range.
By their numbers in this assay, from the lowest: compounds 1, 2, 3 and 4 (each within the scatter of the next).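

Replacing 4-ethylphenyl with 2,4-difluorophenyl on the aromatic carbon of the five-membered ring brings fluorine onto the pendant phenyl for the first time among these compounds, and in this assay the result is a 1.7-fold higher number from compound 1 to compound 4 (0.22 log units; within the scatter). Among the compounds shown here, the earlier step at this phenyl exchanged only one alkyl group for another, so this pair extends the flat picture to a group with no alkyl chain, though only for these compounds. Nothing available here accounts for the absence of a step beyond the scatter.

Because the ethyl group left as the two fluorines entered, this single step cannot separate their contributions. Going by these compounds, a phenyl carrying one fluorine, an unsubstituted phenyl, and a phenyl bearing trifluoromethyl, methoxy or an amine remain open, as does whether any of them would move the number beyond the scatter.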